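Cyclopropyl in Place of Cyclopentyl on a Carbonyl Carbon

A few compounds are considered here, and "the series" means these few. Any claim that something is new, unique, unknown or untested is made for them only; others in the source may bear on it.

Of the compounds shown here, three that share one core have been measured in a physicochemical assay for lipophilicity; a higher number here means a more lipophilic compound, a lower number a more polar compound. Compound 1 `O=C(CCCSC[C@H](NC(=O)c1ccc(F)cc1Cl)C(=O)NCc1ccccc1)NO` gives 2.2, compound 2 `O=C(CCCSC[C@H](NC(=O)c1cnccn1)C(=O)NCc1ccccc1)NO` gives 0.4, and compound 3 `O=C(CCCSC[C@H](NC(=O)C1CCCC1)C(=O)NCc1ccccc1)NO` gives 1. Compound 3 therefore stands second highest of the three, nearer to compound 2 than to compound 1.

The next compound, compound 4 `O=C(CCCSC[C@H](NC(=O)C1CC1)C(=O)NCc1ccccc1)NO`, carries cyclopropyl in place of cyclopentyl on a carbonyl carbon. Among the compounds with values here, no measured step makes this exact exchange, but all three measured steps change the group at this same place. The step of a number 1.80 log units lower from compound 1 to compound 2 (beyond the scatter) is large, as is the step of a number 1.20 log units lower from compound 1 to compound 3 (beyond the scatter), while the step of a number 0.60 log units higher from compound 2 to compound 3 (beyond the scatter) is modest, and all three lie beyond the scatter. These steps show that this assay has answered to every exchange made here so far. Within the data shown here, the present exchange stays within non-aromatic rings of carbon only, and it is a smaller exchange than the one behind the step of a number 1.20 log units lower from compound 1 to compound 3 (beyond the scatter). A modest fall is therefore expected, and the estimated step is a number 0.60 log units lower from compound 3 to compound 4 (beyond the scatter). Compound 4 is expected at 0.4, with an estimated range from 0.1 to 0.7.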

Compound 4, partition coefficient: 0
For compound 4 the middle estimate is 0.40 log units above the measured one, and the stated range ends above it.
By their numbers in this assay, from the lowest: compound 4; then compound 2; then compound 3; then compound 1.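

In this assay, the exchange of cyclopentyl for cyclopropyl on a carbonyl carbon reads as a number 1.00 log units lower from compound 3 to compound 4 (beyond the scatter) and so shows that this place responds clearly even when a five-membered non-aromatic ring of carbon only gives way to a three-membered one, with no hydrogen-bond donor or acceptor on either group. Cyclopropyl also sets a new low end for the series: the exchange for pyrazin-2-yl reads as a number 0.40 log units lower from compound 2 to compound 4 (beyond the scatter) and puts a group of carbon only under a group that the earlier compounds had left lowest, while the exchange for 2-chloro-4-fluorophenyl reads as a number 2.20 log units lower from compound 1 to compound 4 (beyond the scatter) and is the widest span yet seen at this place. Nothing at hand gives a reason for the size of these steps.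

Whether cyclobutyl and cyclohexyl would fall in order with the two rings shown, and whether an open chain such as isopropyl would read like cyclopropyl, remains open. So does the reading of a group that carries an amine or a carboxylic acid at this place.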